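A few compounds are considered here, and "the series" means these few. Any claim that something is new, unique, unknown or untested is made for them only; others in the source may bear on it.

Within the data shown here, in a functional assay on MCF7 cells (Homo sapiens) for antiproliferative activity, read by MTT assay, with a stated time of 48 h (on this read-out lower numbers stand for stronger inhibition and higher numbers for weaker inhibition), compound 2 `COc1ccc(-c2nn(-c3ccccc3)cc2CNc2ccc(C)cc2)cc1` gives 8160 nM as the higher of the two numbers measured so far, which makes it the weaker of the pair. Compound 1 `Cc1ccc(NCc2cn(-c3ccccc3)nc2-c2ccc(Cl)cc2)cc1` gives 3110 nM on the same read-out and carries chloro where compound 2 carries methoxy. Compound 3 `Cc1ccc(NCc2cn(-c3ccccc3)nc2-c2ccc(C)cc2)cc1` is still unmeasured: it has methyl in place of methoxy on an aromatic carbon, 4-methoxyphenyl to 4-methylphenyl, and the count runs methyl in place of methoxy on an aromatic carbon with the rest of the structure unchanged. Among the measured compounds shown here, the only measured step at this place is a 2.6-fold higher number from compound 1 to compound 2 (0.42 log units; beyond the scatter) and it is modest, so with methyl itself untested a modest step toward a lower number is expected in this assay as a rough guide. The expected step is a 1.6-fold lower number from compound 2 to compound 3 (0.21 log units; within the scatter) and no larger change is anticipated. For compound 3 the estimated value is 5000 nM within an expected range from 2000 nM to 12000 nM as the likely span.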

Compound 3, half-maximal inhibitory concentration: 7260 nM
Beside the measured number, compound 3's estimate is 1.5-fold (0.16 log units) below it, and the stated range covers the measured number.
By their numbers in this assay, from the lowest: compound 1; then compounds 3 and 2 (each within the scatter of the next).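

In this assay, methyl in place of methoxy gives a 1.1-fold lower number from compound 2 to compound 3 (0.05 log units; within the scatter), so this position does not separate these two groups, even though methyl has one heavy atom fewer and no hydrogen-bond acceptor. Chloro now stands apart from both: methyl in its place gives a 2.3-fold higher number from compound 1 to compound 3 (0.37 log units; beyond the scatter), in the same direction as the earlier change to methoxy, a 2.6-fold higher number from compound 1 to compound 2 (0.42 log units; beyond the scatter). Nothing available explains why chloro differs from the other two groups.

The compounds shown leave open whether the lower number belongs to chloro alone or would also appear with another halogen such as fluoro or bromo. They also leave open how a quite different group at this position, such as an amine or a carboxylic acid, would compare with these three.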